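The compounds below may be only part of what the source reports. "The series", "measured", "known", "first", "only" and "open" are said of these compounds alone.

Measured in a functional assay on HepG2 cells (Homo sapiens) for cytotoxicity, read by MTT assay, with a stated time of 24 h; a higher number here means a weaker inhibitor, a lower number a stronger inhibitor:

- compound 1 `O=C1/C(=C/c2cccnc2)CN(S(=O)(=O)c2ccc(C(F)(F)F)cc2)C/C1=C\c1ccccc1F` gives 2400 nM
- compound 2 `O=C1/C(=C/c2cccnc2)CN(S(=O)(=O)c2ccccc2)C/C1=C\c1ccccc1C(F)(F)F` gives 5370 nM
- compound 3 `O=C1/C(=C/c2cccnc2)CN(S(=O)(=O)c2ccc([N+](=O)[O-])cc2)C/C1=C\c1ccccc1C(F)(F)F` gives 9370 nM

Compound 3 holds a higher number than compound 1, beyond the scatter, but lies within the scatter of compound 2. Compound 4 `O=C1/C(=C/c2cccnc2)CN(S(=O)(=O)c2ccc(C(F)(F)F)cc2)C/C1=C\c1ccccc1C(F)(F)F` follows from compound 3 by trifluoromethyl in place of nitro on an aromatic carbon. Among the compounds with values here, no measured step makes this exchange directly. Within the data shown here, the one step at hand, a 1.7-fold higher number from compound 2 to compound 3 (0.24 log units; within the scatter), is small. Compound 1 carries the same trifluoromethyl and gives 2400 nM, but it also differs elsewhere. A modestly lower number, not beyond the scatter, is therefore expected in this assay. The expected step is a 1.7-fold lower number from compound 3 to compound 4 (0.23 log units; within the scatter). For compound 4 the estimated value is 5500 nM, with an expected range of 2500 nM to 12000 nM.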

Compound 4, half-maximal inhibitory concentration: 1710 nM
Compound 4: middle estimate off by 3.2-fold (0.51 log units), on the high side; the measured number lies below the stated range.
By their numbers in this assay, from the lowest: compounds 4 and 1 (each within the scatter of the next); then compounds 2 and 3 (each within the scatter of the next).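

In this assay, trifluoromethyl at this position stands apart beyond the scatter from both nitro, with a 5.5-fold lower number from compound 3 to compound 4 (0.74 log units; beyond the scatter), and hydrogen, with a 3.1-fold lower number from compound 2 to compound 4 (0.50 log units; beyond the scatter), whereas nitro and hydrogen had stayed within the scatter of each other. Elsewhere in the molecule, trifluoromethyl in place of fluoro stays within the scatter, with a 1.4-fold lower number from compound 1 to compound 4 (0.15 log units; within the scatter). Nothing measured here accounts for these steps. Going by these compounds, it remains open whether an amine or a carboxylic acid at this position would give a number nearer trifluoromethyl or nearer hydrogen and nitro. Also open, on these data alone, is whether the trifluoromethyl step would hold with fluoro in the other place.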